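Nitrogen substituent changes on the shared core

A few compounds are considered here, and "the series" means these few. Any claim that something is new, unique, unknown or untested is made for them only; others in the source may bear on it.

The shared core carries a variable group on an aromatic nitrogen of a five-membered aromatic ring with 3 nitrogen. Within the data shown here, in a functional assay on HT-29 cells (Homo sapiens) for inhibition, read by luminescence and CellTiter-Glo, with a stated time of 24 h (on this read-out lower numbers stand for an effect already at smaller amounts and higher numbers for an effect only at larger amounts of compound), compound 1 `CN1C(=S)[C@@H](NC(=O)c2nc(Cc3ccccc3)n(CCCC#N)n2)COc2ccccc21` gives 2400 nM, the lowest of the two numbers measured so far. Compound 2 `CN1C(=S)[C@@H](NC(=O)c2nc(Cc3ccccc3)n(C3CCCC3)n2)COc2ccccc21` gives 3530 nM in this assay; the step of a 1.5-fold higher number from compound 1 to compound 2 (0.17 log units; within the scatter) shows that exchanging the chain for a carbocycle at this position left the read-out essentially unchanged.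

Compound 3 `Cc1cnc(-n2nc(C(=O)N[C@H]3COc4ccccc4N(C)C3=S)nc2Cc2ccccc2)nc1` differs from compound 1 by 5-methylpyrimidin-2-yl in place of 3-cyanopropyl on an aromatic nitrogen. Among the measured compounds shown here, the only measured step that bears on this position is the one from compound 1 to compound 2, which stayed within the scatter; no step with an aromatic group at this nitrogen is available, so the entry of a six-membered aromatic ring with 2 hetero atoms is untested here. Given that the single relevant step was small, no step beyond the scatter is expected, and the estimated step is a 1.1-fold higher number from compound 1 to compound 3 (0.03 log units; within the scatter). The value of compound 3 in this assay is therefore estimated at 2600 nM, within a range of 900 nM to 7500 nM.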

Compound 3, half-maximal effective concentration: 1950 nM
For compound 3 the middle estimate is 1.3-fold (0.12 log units) above the measured one, within the range that was stated.
By their numbers in this assay, from the lowest: compounds 3, 1 and 2 (each within the scatter of the next).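

In this assay, an aromatic group on the aromatic nitrogen now joins the open chain and the carbocycle: 5-methylpyrimidin-2-yl gives a 1.2-fold lower number from compound 1 to compound 3 (0.09 log units; within the scatter) and a 1.8-fold lower number from compound 2 to compound 3 (0.26 log units; within the scatter), so compound 3 lies within the scatter of both compounds. Across these three compounds, a nitrile-bearing chain, a saturated carbocycle and a six-membered aromatic ring with 2 hetero atoms all give numbers that cannot be told apart at this position, and no ranking of the three groups can be drawn. No supporting data are available to explain this result.

Going by these compounds, it remains open whether any group at this nitrogen gives a step beyond the scatter, for example a chain ending in a primary amine or a carboxylic acid, or a longer chain than 3-cyanopropyl. On these data alone, it is also open whether the methyl group of 5-methylpyrimidin-2-yl matters, and whether the same tolerance holds when a group other than benzyl sits on the neighbouring ring atom named.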